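Swapping the aromatic ring of a weak growth inhibitor

The compounds below may be only part of what the source reports. "The series", "measured", "known", "first", "only" and "open" are said of these compounds alone.

In a functional assay on NCI-H520 cells (Homo sapiens) (on this read-out lower numbers stand for stronger inhibition of growth and higher numbers for weaker inhibition of growth), compound 1 `O=S(=O)(/C=C/c1ccc(Cl)cc1)Cc1ccc(Nc2ncnc3ccc(Br)cc23)cc1` gives 13000 nM. For the measured compounds named here, compound 2 `O=S(=O)(/C=C/c1ccc(O)cc1)Cc1ccc(Nc2ncnc3ccc(Br)cc23)cc1` gives 27000 nM, the higher of the two numbers so far, which makes it the weaker inhibitor of the pair. Compound 3 `O=S(=O)(/C=C/c1ccc(C(F)(F)F)cc1F)Cc1ccc(Nc2ncnc3ccc(Br)cc23)cc1` is made from compound 2 by a larger swap: 2-fluoro-4-(trifluoromethyl)phenyl in place of 4-hydroxyphenyl on a double-bonded chain carbon bound to a double-bonded chain carbon. Going by the values given here, only one measured step bears on this change: a 2.1-fold higher number from compound 1 to compound 2 (0.32 log units; beyond the scatter), a modest step that came with hydroxy in place of chloro on an aromatic carbon. Like compound 1 at 13000 nM, compound 3 has no hydroxy, so a return towards that number seems a fair expectation. Among the compounds with values here, its fluoro and trifluoromethyl groups, however, appear in no measured compound, so the range must stay wide. The expected step in this assay is modest and downward, a 2.1-fold lower number from compound 2 to compound 3 (0.32 log units; beyond the scatter). For compound 3 the estimated value is 13000 nM, with an expected range from 5000 nM to 30000 nM.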

Compound 3, concentration for 50% growth inhibition: 40000 nM
The estimate for compound 3 lay 3.1-fold (0.49 log units) below the measured number; the whole stated range lies below it.
By their numbers in this assay, from the lowest: compound 1; then compounds 2 and 3 (each within the scatter of the next).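

In this assay, replacing 4-hydroxyphenyl with 2-fluoro-4-(trifluoromethyl)phenyl on the double-bonded chain carbon gives a 1.5-fold higher number from compound 2 to compound 3 (0.17 log units; within the scatter), so even this larger swap leaves compound 3 indistinguishable from compound 2. Removing the hydroxy did not by itself restore the number of compound 1: the comparison with 4-chlorophenyl shows a 3.1-fold higher number from compound 1 to compound 3 (0.49 log units; beyond the scatter), so among these three aromatic groups only 4-chlorophenyl stands apart, and the presence or absence of a hydrogen-bond donor does not sort them. No supporting measurement explains this result.

Fluoro and trifluoromethyl enter together in compound 3, so their separate contributions cannot be read. As far as these compounds go, it remains open whether a methoxy group or an amine on this aromatic ring would give a number lower than that of compound 1.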